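Working notes: ester variation, forecast for compound 4

The source may report more compounds than this note shows. Statements on the series, on what has been measured and on what is new or still open speak of the compounds shown alone.

Measured so far:
- compound 1 `C=C(C)CCOC(=O)C1=C(C)NC(C)=C(C(=O)OC)C1c1cccc([N+](=O)[O-])c1`: 23 nM
- compound 2 `COC(=O)C1=C(C)NC(C)=C(C(=O)OCc2ccccc2)C1c1cccc([N+](=O)[O-])c1`: 25 nM
- compound 3 `COC(=O)C1=C(C)NC(C)=C(C(=O)OCc2cc([N+](=O)[O-])cc([N+](=O)[O-])c2)C1c1cccc([N+](=O)[O-])c1`: 55 nM

In a functional assay on HEK293 cells for antagonist activity at Voltage-dependent L-type calcium channel subunit alpha-1C (Oryctolagus cuniculus), read by FLIPR (a lower number here means a stronger inhibitor, a higher number a weaker inhibitor), compound 3 has the highest number of the three: the nearest step is a 2.2-fold higher number from compound 2 to compound 3 (0.34 log units; beyond the scatter) and the furthest a 2.4-fold higher number from compound 1 to compound 3 (0.38 log units; beyond the scatter), both beyond the scatter. Compound 1 and compound 2 sit together, as a 1.1-fold higher number from compound 1 to compound 2 (0.04 log units; within the scatter) shows.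

Compound 4 `COC(=O)C1=C(C)NC(C)=C(C(=O)OCCc2ccc(Cl)cc2)C1c1cccc([N+](=O)[O-])c1` differs from compound 3 by 4-chlorobenzyl in place of 3,5-dinitrophenyl on a saturated chain carbon bound to an oxygen next to a carbonyl group. The measured step that bears on this is a 2.2-fold higher number from compound 2 to compound 3 (0.34 log units; beyond the scatter), which runs in the opposite direction; the step of a 1.1-fold higher number from compound 1 to compound 2 (0.04 log units; within the scatter) suggests esters without nitro groups give similar numbers. Compound 4 is therefore expected to move back toward compound 1 and compound 2, a step of a 2.2-fold lower number from compound 3 to compound 4 (0.34 log units; beyond the scatter). Compound 4 is estimated at 25 nM, with a range of 10 nM to 60 nM.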

Compound 4, half-maximal inhibitory concentration: 8 nM
For compound 4 the middle estimate is 3.1-fold (0.49 log units) above the measured one; the measured number lies below the stated range.
By their numbers in this assay, from the lowest: compound 4; then compounds 1 and 2 (each within the scatter of the next); then compound 3.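

In this assay this position proves able to go well below the level shared by compound 1 and compound 2: 4-chlorobenzyl gives a 6.9-fold lower number from compound 3 to compound 4 (0.84 log units; beyond the scatter) and also a 3.1-fold lower number from compound 2 to compound 4 (0.49 log units; beyond the scatter) and a 2.9-fold lower number from compound 1 to compound 4 (0.46 log units; beyond the scatter) with no loss against any earlier ester. The gain therefore exceeds the penalty seen with 3,5-dinitrophenyl. Nothing available explains this change.

Compound 4 differs from compound 2 in both the chlorine and the longer chain, so their shares remain unseparated. A benzyl group in this place, without the chlorine, would separate them.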